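The source may report more compounds than this note shows. Statements on the series, on what has been measured and on what is new or still open speak of the compounds shown alone.

In a functional assay on MGC-803 cells (Homo sapiens) for inhibition, read by MTT assay, with a stated time of 72 h (a higher number here means a weaker inhibitor, a lower number a stronger inhibitor), the compounds are compared by how strongly they hold back the growth of a stomach-cancer cell line. Compound 1, whose structure is `O=C(CSc1nc(Nc2ccccc2)c2ccccc2n1)Nc1ccc(Br)cc1`, gives 19300 nM. Compound 2, with structure `O=C(CSc1nc(Nc2ccccc2)c2ccccc2n1)Nc1ccc([N+](=O)[O-])cc1`, reaches only the limit of the measurement, > 50000 nM, so no exact number is known for it. The change from compound 1 to compound 2 is nitro in place of bromo on an aromatic carbon, and it brings an at least 2.5-fold higher number from compound 1 to compound 2 (0.41 log units; beyond the scatter); the size of that step can only be given as a lower bound because of the limit of > 50000 nM in this assay, at which 1 of the 3 values shown sits.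

Compound 3 has the structure `C=CC(=O)Nc1cccc(NC(=O)CSc2nc(Nc3cccc(Br)c3)c3ccccc3n2)c1` and gives 11900 nM. How its core differs from that of compound 1 is not broken down here; the two values lie within the scatter of each other.

Compound 4, with structure `C=CC(=O)Nc1cccc(NC(=O)CSc2nc(Nc3cccc([N+](=O)[O-])c3)c3ccccc3n2)c1`, has not yet been measured. It differs from compound 3 by nitro in place of bromo on an aromatic carbon. This is the same kind of change as from compound 1 to compound 2, though not the same: there the nitro sat para to a large group, here it sits meta to a large group. Resting on the weakening seen in an at least 2.5-fold higher number from compound 1 to compound 2 (0.41 log units; beyond the scatter), the step is expected to be a 2.9-fold higher number from compound 3 to compound 4 (0.47 log units; beyond the scatter), which would place compound 4 near the limit of the assay. Compound 4 is therefore estimated at 35000 nM, within a range from 14000 nM to 100000 nM.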

Compound 4, half-maximal inhibitory concentration: > 50000 nM
Compound 4 ended at the assay's limit; the forecaster's own chance of this, stated with the estimate: 45%; middle value at least 1.4-fold (0.15 log units) away from the limit.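

In this assay, putting nitro in place of bromo on an aromatic carbon of the core of compound 3 gives an at least 4.2-fold higher number from compound 3 to compound 4 (0.62 log units; beyond the scatter), so the change that weakened the core of compound 1 also weakens this second core, and on both the step lies beyond the scatter. Set side by side, the two steps read: the same change on two cores in this assay, an at least 2.5-fold higher number (0.41 log units; beyond the scatter) from compound 1 to compound 2 and an at least 4.2-fold higher number (0.62 log units; beyond the scatter) from compound 3 to compound 4; the limit leaves it open whether they differ. Compound 4 stands at a limit of the assay and not at a number, as does compound 2, so each step is only a lower bound: the direction of the change carries over between these two cores, but nothing shows that its size stays the same or that it shifts, and two cores are too few to call it a general rule: the limit of > 50000 nM in this assay, at which 2 of the 4 values shown sit.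

The compounds shown leave open whether some other group in place of the bromo, such as an amine, a carboxylic acid or a methoxy group, would keep or improve the growth inhibition seen with bromo on these cores. They also leave open how far the two nitro compounds really lie past the limit, and why nitro gives weaker inhibition than bromo here.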